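A few compounds are considered here, and "the series" means these few. Any claim that something is new, unique, unknown or untested is made for them only; others in the source may bear on it.

Measured so far:
compound 1 `CCOC(=O)c1[nH]c2ccccc2c1C(=O)c1cc(OC)c(OC)c(OC)c1N` — 5630 nM
compound 2 `CCOC(=O)c1[nH]c2ccc(OC)cc2c1C(=O)c1cc(OC)c(OC)c(OC)c1N` — 5150 nM
compound 3 `COc1cc(Cc2c[nH]c3ccccc23)c(N)c(OC)c1OC` — > 100000 nM

Compound 1 and compound 2 share one core; in a functional assay on HT-29 cells (Homo sapiens) for cytotoxicity, read by sulforhodamine B assay, with a stated time of 48 h (a higher number here means a weaker inhibitor of growth, a lower number a stronger inhibitor of growth), compound 2 carries methoxy in place of hydrogen on an aromatic carbon and the step is a 1.1-fold lower number from compound 1 to compound 2 (0.04 log units; within the scatter). Compound 3 is another matter: the value reported for it is a limit of the assay and not a number, as the limit of > 100000 nM in this assay, at which 1 of the 3 values shown sits, shows. How the core of compound 3 differs from the core of compound 1 is not broken down here.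

Compound 4 `COc1ccc2c(Cc3cc(OC)c(OC)c(OC)c3N)c[nH]c2c1` stands to compound 3 as compound 2 stands to compound 1: methoxy in place of hydrogen on an aromatic carbon. The place line reads the same word for word, so this is the same change. Compound 4 is expected to give a step that the limit leaves unreadable from compound 3 to compound 4 in this assay. That expectation rests on the measured step of a 1.1-fold lower number from compound 1 to compound 2 (0.04 log units; within the scatter), a change that left the number essentially where it was. Compound 4 is therefore estimated at 150000 nM, with a likely span from 60000 nM to 400000 nM, and in all likelihood this assay will again report only a limit for compound 4.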

Compound 4, concentration for 50% growth inhibition: 74800 nM
Compound 4: middle estimate off by 2.0-fold (0.30 log units), on the high side; low and high end bracket the measured number.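

Carried to the second core, methoxy in place of hydrogen on an aromatic carbon gives an at least 1.3-fold lower number from compound 3 to compound 4 (0.12 log units; that floor lies within the scatter) in this assay, and set beside the step on the first core it reads: the same change on two cores in this assay, a 1.1-fold lower number (0.04 log units; within the scatter) from compound 1 to compound 2 and an at least 1.3-fold lower number (0.12 log units; that floor lies within the scatter) from compound 3 to compound 4; the limit leaves it open whether they differ.
Compound 3 stands at > 100000 nM, which is a limit of the assay and not a number.
As far as these compounds go, the two cores therefore show no conflict, but this does not show that the change carries over unaltered: the true size of the second step stays unknown, and it could match the first step or exceed it.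

Methoxy is the only entering group shown, so whether hydroxyl, fluorine, an amine or a longer chain such as ethoxy would behave alike on the two cores stays open. Also open is whether the same step would hold in a read-out other than this assay, which is the only one shown here.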